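Moving a methyl on the aryl ring of an alkyne

This account rests on a few compounds, and the source may have more. Where it says the series, first, only, none or still open, it means among the compounds named here.

Measured compounds in an assay on HEK293 cells for displacement of a labelled ligand from metabotropic glutamate receptor 5 (Homo sapiens), with a stated time of 2 h; on this read-out higher numbers stand for weaker inhibition and lower numbers for stronger inhibition: compound 1 `Cc1cccc(C#Cc2ccc3c(n2)CCN(C)C3=O)c1` gives 820 nM. Compound 2 `Cc1cccc(C#Cc2ccc3c(n2)CCN(C2CCCC2)C3=O)c1` gives 670 nM. Compound 3 `Cc1ccccc1C#Cc1ccc2c(n1)CCN(C1CCCCC1)C2=O` gives only a limit, > 32000 nM.

Compound 3 thus stands at the edge of what this assay reports (the limit of > 32000 nM in this assay, at which 1 of the 3 values shown sits), with no number at all. Compound 4 `Cc1cccc(C#Cc2ccc3c(n2)CCN(C2CCCCC2)C3=O)c1` differs from it by 3-methylphenyl in place of 2-methylphenyl on a triple-bonded carbon. Among the measured compounds shown here, no measured pair differs in that change alone. For the measured compounds named here, the one measured step, a 1.2-fold lower number from compound 1 to compound 2 (0.09 log units; within the scatter), concerns only the group on the amide-type nitrogen, and both of those compounds carry 3-methylphenyl, as compound 4 does, with a carbon ring on the nitrogen like compound 2. Compound 4 is therefore expected to fall near compounds 1 and 2, a step of an at least 45-fold lower number from compound 3 to compound 4 (1.66 log units; beyond the scatter), at roughly 700 nM (range 250 nM to 2500 nM).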

Compound 4, inhibition constant: 3210 nM
Estimate against measurement, compound 4: 4.6-fold (0.66 log units) below; measured number above the stated range.
By their numbers in this assay, from the lowest: compounds 2 and 1 (each within the scatter of the next); then compound 4. At a limit, above all of these: compound 3.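

Moving the methyl, so that 3-methylphenyl replaces 2-methylphenyl on a triple-bonded carbon, gives an at least 9.9-fold lower number from compound 3 to compound 4 (0.99 log units; beyond the scatter). The value of compound 3 is a limit of the assay, so this step has only a minimum size: the limit of > 32000 nM in this assay, at which 1 of the 4 values shown sits.

The group on the amide-type nitrogen, which made no clear difference in the earlier step, now does: cyclohexyl gives a 4.8-fold higher number from compound 2 to compound 4 (0.68 log units; beyond the scatter) and a 3.9-fold higher number from compound 1 to compound 4 (0.59 log units; beyond the scatter).

On these data alone, the effect of 2-methylphenyl is seen only alongside cyclohexyl, so its effect with methyl or cyclopentyl on the nitrogen stays open. Also open, as far as these compounds go, is how a chloro or methoxy group in place of the methyl would read.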